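A few compounds are considered here, and "the series" means these few. Any claim that something is new, unique, unknown or untested is made for them only; others in the source may bear on it.

Three compounds on two different cores were measured in an assay for inhibition of leukotriene C4 synthase (Homo sapiens), read by LC-MS, with stated times of 15 min and 30 min; on this read-out lower numbers stand for stronger inhibition and higher numbers for weaker inhibition. Compound 1 `COc1cc(N(CC2CC2)c2ccc(F)c3ccccc23)cnc1C(=O)[C@H]1C[C@@H]1C(=O)O` gives 0.758 nM in this assay, and compound 2 `COc1cc(N(CC(C)C)c2ccc(F)c3ccccc23)cnc1C(=O)[C@H]1C[C@@H]1C(=O)O` gives 0.381 nM. Compound 3 `COc1cc(N(CC2CC2)c2cc(Cl)c(F)cc2F)cnc1C(=O)[C@H]1C[C@@H]1C(=O)O`, built on the second core, gives 1.97 nM; how the cores of compound 1 and compound 3 differ is not broken down here. The change from compound 1 to compound 2 is isopropyl in place of cyclopropyl on a saturated chain carbon bound to a nitrogen on an aromatic ring. Compound 4 `COc1cc(N(CC(C)C)c2cc(Cl)c(F)cc2F)cnc1C(=O)[C@H]1C[C@@H]1C(=O)O` has not yet been measured in this assay. It stands to compound 3 exactly as compound 2 stands to compound 1, since the change is isopropyl in place of cyclopropyl on a saturated chain carbon bound to a nitrogen on an aromatic ring. The step from compound 3 to compound 4 is therefore expected to be about a 2.0-fold lower number from compound 3 to compound 4 (0.29 log units; within the scatter). This expectation rests on the single measured case of the same change, which made a 2.0-fold lower number from compound 1 to compound 2 (0.30 log units; within the scatter). Compound 4 is accordingly estimated at 1 nM in this assay, most likely between 0.4 nM and 2.5 nM.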

Compound 4, half-maximal inhibitory concentration: 0.7 nM
Estimate against measurement, compound 4: 1.4-fold (0.15 log units) above; low and high end bracket the measured number.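

In this assay, isopropyl in place of cyclopropyl gives a 2.8-fold lower number from compound 3 to compound 4 (0.45 log units; beyond the scatter), so compound 4 keeps the lower number seen for this change on the core of compound 1. Two pairs cannot show that the change would behave the same way on any further core, and they do not explain why the number moves. Within these two pairs, though, the change carries over from one core to the other at much the same size: the same change on two cores in this assay, a 2.0-fold lower number (0.30 log units; within the scatter) from compound 1 to compound 2 and a 2.8-fold lower number (0.45 log units; beyond the scatter) from compound 3 to compound 4, 1.4-fold (0.15 log units) apart, within the scatter of two such steps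

Going by these compounds, how other groups would compare at this place stays open, for example a cyclobutyl ring or a longer chain such as n-pentyl. These compounds also leave open whether an amine could stand in for the carboxylic acid.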